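This account rests on a few compounds, and the source may have more. Where it says the series, first, only, none or still open, it means among the compounds named here.

Three compounds have been measured in an ADME assay on Vero cells (Chlorocebus sabaeus) for cytotoxicity, read by neutral red uptake, tested at 12.3 ug/mL; a higher number here means a weaker effect of the compound at the concentration tested, a lower number a stronger effect:

compound 1, `O=C1CSC(c2c(Cl)cccc2Cl)N1CCN1CCCCC1`, gives 100%
compound 2, `COc1ccc(C2SCC(=O)N2CCN2CCCCC2)cc1`, gives 100%
compound 3, `O=C1CSC(c2cccc(Cl)c2)N1CCN1CCCCC1`, gives 100%

Compound 3 stands level with compound 1 and compound 2 at the digits shown; the differences between them lie within the usual scatter of this kind of measurement, so none of the three can be set above or below another. Compound 4, `O=C1CSC(c2ccc(O)cc2)N1CCN1CCCCC1`, has not been measured. It differs from compound 3 in one place: 4-hydroxyphenyl in place of 3-chlorophenyl on a saturated ring carbon. The three measured compounds carry different groups on that saturated ring carbon yet give the same reading, so the step of no change at the digits printed from compound 3 to compound 4 (within the scatter) is expected to be none beyond the scatter. Compound 4 is therefore expected to give 100%, within 85% to 100%.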

Compound 4, a percentage reported as activity, at one concentration (the size of the read-out at that concentration, not a potency): 100%
Beside the measured number, compound 4's estimate shows no gap at the digits printed; measured number inside the range.
By their numbers in this assay, from the lowest: compounds 1, 2, 3 and 4 (each within the scatter of the next).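

In this assay, 4-hydroxyphenyl brings a hydrogen-bond donor and a hydrogen-bond acceptor that 3-chlorophenyl lacks, yet the reading holds (no change at the digits printed from compound 3 to compound 4 (within the scatter)). Removing the methyl from the oxygen of compound 2 likewise leaves the reading where it was (no change at the digits printed from compound 2 to compound 4 (within the scatter)), so a free hydroxyl on the aromatic ring fits the same flat picture as methoxy and chlorine. Nothing available explains this flat result. On these data alone, all four compounds carry a substituted phenyl ring on this saturated ring carbon, so it remains open whether an amine or a carboxylic acid on that ring, or a longer chain in its place, would lower the reading.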